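Chloro on the Shared Core: An Unreadable Starting Point

The source may hold more compounds than are shown below. What is called first, only, known or untested is meant among the compounds shown, and "the series" means these compounds.

Compound 1 `O=C(Nc1cccc2cccnc12)c1ncccn1` stands at a limit in a functional assay on BXPC-3 cells (Homo sapiens) for inhibition, read by MTT assay, with a stated time of 72 h; a higher number here means a weaker inhibitor, a lower number a stronger inhibitor: compound 1 gives > 10000 nM, a limit of the assay rather than a number. Compound 2 `Cc1ccc2cccc(NC(=O)c3ncccn3)c2n1` likewise gives only a limit in this assay, > 10000 nM. For the measured compounds named here, the single measured step, a step that the two limits leave unreadable from compound 1 to compound 2, is unreadable because both values sit at the limit of > 10000 nM in this assay, at which 2 of the 2 values shown sit. Compound 3 `O=C(Nc1cc(Cl)cc2cccnc12)c1ncccn1` differs from compound 1 by chloro in place of hydrogen on an aromatic carbon. Going by the values given here, no measured step gives a readable size for such a change, so no direction can be drawn. Compound 3 is therefore expected to stay near that limit, estimated at 15000 nM (range 3000 nM to 60000 nM), an expected step that the limit leaves unreadable from compound 1 to compound 3.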

Compound 3, half-maximal inhibitory concentration: > 10000 nM
Compound 3: no number, only a limit; the forecaster's own chance of this, stated with the estimate: 75%; the middle value is on the limit's open side.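

In this assay, for the compounds shown here, compound 3 gives > 10000 nM as a limit of the assay, so no step from compound 1 to compound 3 can be read: the limit of > 10000 nM in this assay, at which 3 of the 3 values shown sit. The compounds shown leave open whether any change on the shared core gives a readable value.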